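Ring swap on the shared core: efficacy steady

This account rests on a few compounds, and the source may have more. Where it says the series, first, only, none or still open, it means among the compounds named here.

Compound 1 `NS(=O)(=O)c1ccc(-c2nc(C(c3ccc(F)cc3)c3ccc(F)cc3)sc2CC(=O)O)cc1`, compound 2 `O=C(O)Cc1sc(C(c2ccc(F)cc2)c2ccc(F)cc2)nc1-c1ccc(Cl)cc1` and compound 3 `O=C(O)Cc1sc(C(c2ccc(F)cc2)c2ccc(F)cc2)nc1-c1cn[nH]c1` share one core and differ only in the group on an aromatic carbon of it. In an in vitro functional assay on HEK285-7 cells for antagonist activity at prostaglandin D2 receptor 2 (Homo sapiens), read by BRET and beta-arrestin recruitment (on this read-out higher numbers stand for larger maximal responses and lower numbers for smaller maximal responses), compound 1 gives 80%, compound 2 gives 80% and compound 3 gives 80%. The steps of no change at the digits printed from compound 1 to compound 2 (within the scatter), no change at the digits printed from compound 1 to compound 3 (within the scatter) and no change at the digits printed from compound 2 to compound 3 (within the scatter) all stay within the scatter, so compound 3 stands level with compound 1 and compound 2. Compound 4 `O=C(O)Cc1sc(C(c2ccc(F)cc2)c2ccc(F)cc2)nc1-c1ccnc(O)c1` carries the change (2-hydroxypyridin-4-yl in place of 1H-pyrazol-4-yl on an aromatic carbon). All three measured swaps at this position bear on it, and none moved the maximal response, so no step beyond the scatter is expected here. Compound 4 is estimated at 80%, between 70% and 90%. The expected step is no change at the digits printed from compound 3 to compound 4 (within the scatter).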

Compound 4, largest response reached (reported as efficacy), in percent of the reference or control that the assay uses: 60%
Beside the measured number, compound 4's estimate is 20 percentage points above it, outside the stated range (below it).
By their numbers in this assay, from the lowest: compound 4; then compounds 1, 2 and 3 (each within the scatter of the next).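

Placing 2-hydroxypyridin-4-yl on this aromatic carbon gives a number 20 percentage points lower from compound 3 to compound 4 (beyond the scatter) in this assay and also a number 20 percentage points lower from compound 2 to compound 4 (beyond the scatter) and a number 20 percentage points lower from compound 1 to compound 4 (beyond the scatter) as the first steps at this position beyond the scatter. The maximal response therefore does depend on the group here, and the level values seen with 1H-pyrazol-4-yl, 4-chlorophenyl and 4-sulfamoylphenyl do not hold for every ring at this position. Nothing available explains the lower value.

On these data alone, whether the hydroxy group or the ring nitrogen goes with the lower response stays open. An amine or a methoxy group in place of the hydroxy group on the same ring would bear on this.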